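Notes on a quinoline-free core series: fluoro to cyclohexyl

This account rests on a few compounds, and the source may have more. Where it says the series, first, only, none or still open, it means among the compounds named here.

Measured compounds:
compound 1 `Fc1ccc2ncc(-c3nn[nH]n3)cc2c1` gives 50 mg/kg in a functional assay on the whole organism (strain Sprague-Dawley) for inhibition, with Rattus norvegicus as the target; on this read-out higher numbers stand for an effect only at larger amounts of compound and lower numbers for an effect already at smaller amounts
compound 2 `Fc1cc(F)c2ncc(-c3nn[nH]n3)cc2c1` gives > 50 mg/kg in this assay

Compound 1 carries the only number shown in this assay; the one further value in the series is a limit. For compound 2 the value of > 50 mg/kg is a limit of the assay, not a number, as the limit of > 50 mg/kg in this assay, at which 1 of the 2 values shown sits, records. Hence the step of a number no lower from compound 1 to compound 2 (the limit leaves the size open) cannot be sized.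

Compound 3 `c1nc2ccc(C3CCCCC3)cc2cc1-c1nn[nH]n1` is not yet measured. Against compound 1 the change is cyclohexyl in place of fluoro on an aromatic carbon. No measured step bears on this change: the single step shown swaps hydrogen for fluoro, and its size is not readable. With nothing to lean on, compound 3 is expected to sit within the scatter of compound 1, and the step of no change at the digits printed from compound 1 to compound 3 (within the scatter) is therefore expected to be about none beyond the scatter. The estimate for compound 3 is 50 mg/kg, with a range from 20 mg/kg to 100 mg/kg, and a fair chance that only a limit is reported.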

Compound 3, minimum effective dose: > 25 mg/kg
Compound 3 was reported as a limit (the forecaster's own chance of this, stated with the estimate: 40%); the middle value does not contradict the limit.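

In this assay compound 3 gives > 25 mg/kg, which is a limit and not a number. No step can be read between compound 1 and compound 3: the limit of > 25 mg/kg in this assay, at which 1 of the 3 values shown sits.

The compounds shown leave open whether cyclohexyl in place of fluoro on the shared core changes the minimum effective dose at all, and by how much.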